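Dimethylamino for methoxy on the aromatic ring

This account rests on a few compounds, and the source may have more. Where it says the series, first, only, none or still open, it means among the compounds named here.

compound 1 `COc1ccc2nc(C)cc(NCc3ccc(F)c(C(F)(F)F)c3)c2c1` gives 14300 nM
compound 2 `COc1cccc(CNc2cc(C)nc3ccc(OC)cc23)c1` gives 12500 nM

Both compounds were tested in a functional assay on MCF-10A cells (Homo sapiens) for antiproliferative activity, with a stated time of 48 h; a lower number here means that less compound is needed, a higher number that more compound is needed for the effect. Compound 2, at 12500 nM, lies within the scatter of compound 1, so the two numbers cannot be ordered.

Compound 3 `COc1ccc2nc(C)cc(NCc3cccc(N(C)C)c3)c2c1` differs from compound 2 by having dimethylamino in place of methoxy on an aromatic carbon, meta to a large group (dimethylamino in place of methoxy on an aromatic carbon). Among the compounds with values here, no measured pair shows the effect of this change, so the expectation is weakly founded. No step beyond the scatter is expected in this assay, and neither direction is favoured. The expected change is a 1.0-fold lower number from compound 2 to compound 3 (0.02 log units; within the scatter), an estimate that stays within the scatter. For compound 3 the estimated value is 12000 nM, with an expected range from 5000 nM to 30000 nM.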

Compound 3, half-maximal effective concentration: 14000 nM
Compound 3: middle estimate off by 1.2-fold (0.07 log units), on the low side; the range from low to high includes it.
By their numbers in this assay, from the lowest: compounds 2, 3 and 1 (each within the scatter of the next).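

With compound 3, the series gains its first pair differing only at this aromatic carbon, meta to a large group. In this assay, dimethylamino in place of methoxy gives a 1.1-fold higher number from compound 2 to compound 3 (0.05 log units; within the scatter), so this read-out does not separate the two groups at this position. Nothing measured here offers an explanation for this result.

As far as these compounds go, it remains open whether any group at this carbon would give a step beyond the scatter, for example a primary amine, a carboxylic acid or a longer alkoxy chain. The pair also comes from a single assay, so it does not show whether the two groups would remain inseparable in another read-out.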